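Adding an arylamino group to compound 1

The source may report more compounds than this note shows. Statements on the series, on what has been measured and on what is new or still open speak of the compounds shown alone.

Compound 1 `CCN1CCc2c(sc(NC=O)c2C(N)=O)C1` is the reference point here. In a functional assay (strain AB) with Danio rerio as the target, read by microscopy, with a stated time of 1 h (a higher number here means that more compound is needed for the effect, a lower number that less compound is needed), compound 1 gives > 25000 nM as a limit of the assay and not a number. In this assay compound 2 `C[N+]1(CC2CCC2)CCc2c(sc(NC(=O)Nc3ccc(Cl)cc3)c2C(N)=O)C1` reads 210 nM and carries a substituted phenylamino group on the corresponding carbonyl carbon, but it also differs from compound 1 elsewhere. Among the compounds with values here, compound 3 `CCN1CCc2c(sc(NC(=O)Nc3cccc(C)c3)c2C(N)=O)C1` keeps the rest of compound 1 and takes (3-methylphenyl)amino in place of hydrogen on a carbonyl carbon as its only change. Within the data shown here, a large step to a lower number is expected in this assay on the strength of compound 2 at 210 nM as the only measured compound with such a group. The estimated step of an at least 16-fold lower number from compound 1 to compound 3 (1.22 log units; beyond the scatter) is a rough one. For compound 3 the expected value is 1500 nM with 300 nM to 10000 nM as the estimated range.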

Compound 3, half-maximal effective concentration: 13000 nM
Beside the measured number, compound 3's estimate is 8.7-fold (0.94 log units) below it; the whole stated range lies below it.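

With the rest of compound 1 kept, (3-methylphenyl)amino in place of hydrogen on a carbonyl carbon gives, in this assay, an at least 1.9-fold lower number from compound 1 to compound 3 (0.28 log units; that floor lies within the scatter). The step is only a floor, because compound 1 carries a limit of the assay and not a number: the limit of > 25000 nM in this assay, at which 1 of the 3 values shown sits.

Compound 3 does give a number, 13000 nM, so further changes at this carbonyl carbon can be read against a measured value. The compounds shown leave open how much of the step belongs to the aromatic ring and how much to the methyl group; a plain phenylamino or a cyclohexylamino group in the same place would separate the two. Also open, as far as these compounds go, is whether a smaller group there, such as methoxy or methylamino, gives a number at all in this assay.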